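The compounds below may be only part of what the source reports. "The series", "measured", "known", "first", "only" and "open" are said of these compounds alone.

For the measured compounds named here, compound 1, `CCC/C=C/C(=O)N(Cc1ccc(OC)c(O)c1)c1cc(OC)c(OC)c(OC)c1`, is the more active of the two compounds measured so far. In a functional assay on HCT-116 cells (Homo sapiens) for inhibition, read by MTT assay, with a stated time of 48 h (on this read-out lower numbers stand for stronger inhibition and higher numbers for weaker inhibition), compound 1 gives 95 nM, the lowest number in the set. Going by the values given here, the only other measured compound, compound 2 with the structure `COc1ccc(N(Cc2cc(OC)c(OC)c(OC)c2)C(=O)CN=[N+]=[N-])cc1O`, is far weaker: in this assay compound 2 gives 38800 nM, a gap well beyond the scatter of repeated measurements. Compound 2 differs from compound 1 in several places at once, so nothing about any single change can be read from that pair.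

Compound 3, `COc1ccc(CN(C(=O)/C=C/CBr)c2cc(OC)c(OC)c(OC)c2)cc1O`, is still unmeasured. It differs from compound 1 in one place: bromo in place of ethyl on a saturated chain carbon bound to a double-bonded chain carbon. The rest of the molecule, including the double-bonded chain carbon and the shared core, is unchanged. Among the compounds with values here, with no measured pair that isolates such a swap, the expectation must rest on compound 1 alone, and a small step in either direction, or none beyond the scatter, seems most likely. The expected step from compound 1 to compound 3 is a 1.6-fold higher number from compound 1 to compound 3 (0.20 log units; within the scatter). Compound 3 is therefore estimated at 150 nM, within a range from 30 nM to 800 nM.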

Compound 3, half-maximal inhibitory concentration: 59 nM
For compound 3 the middle estimate is 2.5-fold (0.41 log units) above the measured one, within the range that was stated.
By their numbers in this assay, from the lowest: compounds 3 and 1 (each within the scatter of the next); then compound 2.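

In this assay, bromo in place of ethyl on a saturated chain carbon bound to a double-bonded chain carbon gives a 1.6-fold lower number from compound 1 to compound 3 (0.21 log units; within the scatter) and so leaves the reading within the usual scatter. For the compounds shown here, this is the first measured step that isolates a single place on the molecule, and it shows that this position can lose ethyl, with its two carbons, and take a single bromine without any measurable change in this cell assay. Nothing measured here explains why these two groups read alike.

Going by these compounds, the reach of this result remains open, since a single swap at one position cannot show how much variation the chain end will accept: a longer chain, an amine or a carboxylic acid on the same carbon might read very differently from bromo and ethyl. It is also unknown whether the match between compound 1 and compound 3 would hold in other cell lines or at other exposure times, and the compounds shown offer no way to tell.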